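The source may hold more compounds than are shown below. What is called first, only, known or untested is meant among the compounds shown, and "the series" means these compounds.

Working notes on the series built around the shared core of compound 1 `CC1CCC(Oc2cccc3ccc(N)nc23)C1`, in which the ether substituent is varied. In an assay on cells with melanin-concentrating hormone receptor 1 (Homo sapiens) as the target, read by radioligand binding (on this read-out lower numbers stand for stronger inhibition and higher numbers for weaker inhibition), compound 1 gives 823 nM, the highest of the two numbers shown. Compound 3 `Nc1ccc2cccc(OC3CCCCCC3)c2n1` gives 137 nM in this assay, and the gap from compound 1 lies beyond the usual scatter. Compound 2 `CC(CC(C)(C)C)Oc1cccc2cccnc12` reaches only a limit of this assay, > 2000 nM, so no number stands for it (the limit of > 2000 nM in this assay, at which 1 of the 3 values shown sits). Going by the values given here, no two measured compounds differ in a single place, so no measured step is quantified.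

Compound 4 `Nc1ccc2cccc(OCC3CCOC3)c2n1` is still to be measured in this assay. It differs from compound 1 in one place: (oxolan-3-yl)methyl in place of 3-methylcyclopentyl on an oxygen on an aromatic ring. Among the compounds with values here, no measured pair carries this change, so the expectation rests on the values of compounds 1 and 3 alone. The step expected is a 1.9-fold higher number from compound 1 to compound 4 (0.29 log units; within the scatter), that is toward weaker inhibition, beyond the scatter. Compound 4 is estimated at 1600 nM in this assay, within 500 nM to 5000 nM, with a real chance that only a limit is returned.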

Compound 4, half-maximal inhibitory concentration: 115 nM
Compound 4: the middle estimate sits 14-fold (1.14 log units) above what was measured, outside the stated range (below it).
By their numbers in this assay, from the lowest: compounds 4 and 3 (each within the scatter of the next); then compound 1. At a limit, above all of these: compound 2.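

Going by these compounds alone, on the oxygen on an aromatic ring, the one quantified single-place step so far is the change from 3-methylcyclopentyl to (oxolan-3-yl)methyl, which gives a 7.2-fold lower number from compound 1 to compound 4 (0.85 log units; beyond the scatter) in this assay. The two groups match in 6 heavy atoms and in one five-membered non-aromatic ring, but the entering group carries 1 hydrogen-bond acceptor and the leaving group 0, so this position accepts a ring hetero atom without loss in this assay. Compound 4 at 115 nM and compound 3 at 137 nM stand within the scatter of each other.

This single pair cannot separate the ring oxygen from the altered attachment of the ring, and no measured property here accounts for the step. From the compounds shown here alone, how an amine such as piperidine or a carboxylic acid would fare on this oxygen remains open.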